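This account rests on a few compounds, and the source may have more. Where it says the series, first, only, none or still open, it means among the compounds named here.

Working notes on the series.

Compound 1 `C=C1C(=O)[C@]23C[C@@]1(O)CC[C@H]2c1ccc(O)c(C)c1[C@@H]3Cn1cc(-c2ccccc2)nn1` carries a phenyl on the triazole; compound 2 `C=C1C(=O)[C@]23C[C@@]1(O)CC[C@H]2c1ccc(O)c(C)c1[C@@H]3Cn1cc(-c2ccc(F)cc2)nn1` carries a 4-fluorophenyl in its place. In a functional assay on SMMC-7721 cells (Homo sapiens) for cytotoxicity, read by MTT assay, with a stated time of 4 days (a higher number here means a weaker inhibitor, a lower number a stronger inhibitor), compound 1 gives 1320 nM. In this assay compound 2 gives 850 nM. The change between them, (fluoro in place of hydrogen on an aromatic carbon), gives a 1.6-fold lower number from compound 1 to compound 2 (0.19 log units; within the scatter), so the two values are not separated by this assay.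

Compound 3 `C=C1C[C@]23C[C@@]1(O)CC[C@H]2c1cc(Br)c(O)c(C)c1[C@@H]3Cn1cc(-c2ccccc2)nn1` has a different core; how its core differs from that of compound 1 is not broken down here. In this assay compound 3 gives only a limit, > 20000 nM, and not a number; the limit of > 20000 nM in this assay, at which 1 of the 3 values shown sits, marks where it sits.

Compound 4 `C=C1C[C@]23C[C@@]1(O)CC[C@H]2c1cc(Br)c(O)c(C)c1[C@@H]3Cn1cc(-c2ccc(F)cc2)nn1` is compound 3 with the same change applied as from compound 1 to compound 2, namely (fluoro in place of hydrogen on an aromatic carbon); the place is the same in both pairs. Compound 4 has not yet been measured in this assay.

Expectation for compound 4 rests on two things: the step from compound 1 to compound 2, a 1.6-fold lower number from compound 1 to compound 2 (0.19 log units; within the scatter), lies within the scatter, and compound 3 gives only a limit, > 20000 nM. The step from compound 3 to compound 4 is therefore expected to be small, about a step that the limit leaves unreadable from compound 3 to compound 4, and compound 4 is expected most likely to return only a limit as well. The estimate for compound 4 in this assay is 25000 nM, with a range from 10000 nM to 60000 nM.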

Compound 4, half-maximal inhibitory concentration: > 20000 nM
Compound 4 ended at the assay's limit; the forecaster's own chance of this, stated with the estimate: 70%; the middle value lies beyond the limit too.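

In this assay compound 3 gives only a limit, > 20000 nM. Compound 4 also gives only a limit, > 20000 nM, so the step from compound 3 to compound 4 cannot be read: the limit of > 20000 nM in this assay, at which 2 of the 4 values shown sit.

The compounds shown leave open whether phenyl to 4-fluorophenyl changes the cytotoxicity on the core of compound 3, and how far either compound lies beyond its limit.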